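Oral tail flick series: acylated amino acid analogues, working notes

The compounds below may be only part of what the source reports. "The series", "measured", "known", "first", "only" and "open" are said of these compounds alone.

Measured so far:
compound 1, `O=C(O)CC[C@H](NC(=O)CN(c1nc(Cl)nc2[nH]cnc12)C1CC1)C(=O)O`, 29.5%
compound 2, `CCOC(=O)CN(c1nc(Cl)nc2c1ncn2C1CCCCO1)C1CC1`, 11.9%
compound 3, `NC(=O)CC[C@H](NC(=O)CN(c1nc(Cl)nc2[nH]cnc12)C1CC1)C(=O)OCc1ccccc1`, 31.1%

All three values come from a functional assay on the whole organism (Tail, strain ICR) with Mus musculus as the target, in the tail flick test, with a stated time of 150 min, at a dose of 25 umol/kg by the oral route; a higher number here means a stronger effect of the compound at the dose given, a lower number a weaker effect. Compound 1 and compound 3 lie within the scatter of each other; compound 2 lies beyond the scatter, below compound 1. Going by the values given here, no two measured compounds differ in a single place, so no step size is established. Compound 4, `CC(C)C[C@H](NC(=O)CN(c1nc(Cl)nc2[nH]cnc12)C1CC1)C(=O)O`, differs from compound 1 in one place: isopropyl in place of carboxymethyl on a saturated chain carbon, two bonds along the chain from an amide-type nitrogen and a carbonyl carbon. Among the compounds with values here, with no measured step of this kind to rest on, a shift beyond the scatter in this assay is not anticipated from compound 1 to compound 4, though a modest fall is as plausible as none. Compound 4 is expected to give about 24% in this assay, between 10% and 40%, an estimated step of a number 5.5 percentage points lower from compound 1 to compound 4 (within the scatter).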

Compound 4, a percentage reported as activity, at one dose (the size of the read-out at that dose, not a potency): 9.13%
Compound 4: the middle estimate sits 14.9 percentage points above what was measured; measured number below the stated range.
By their numbers in this assay, from the lowest: compounds 4 and 2 (each within the scatter of the next); then compounds 1 and 3 (each within the scatter of the next).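

In this assay, going by these compounds alone, isopropyl in place of carboxymethyl on a saturated chain carbon, two bonds along the chain from an amide-type nitrogen and a carbonyl carbon, gives the first single-place step (a number 20.4 percentage points lower from compound 1 to compound 4 (beyond the scatter)). Within the data shown here, the read-out at this dose therefore depends on the group at this position, which the earlier compounds could not show. No measurement shown here explains the step. Still open, as far as these compounds go, is whether an amine, a hydroxyl or a straight butyl chain at this position would give a read-out nearer compound 1 or compound 4.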